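Removing the chloro group from compound 3

A few compounds are considered here, and "the series" means these few. Any claim that something is new, unique, unknown or untested is made for them only; others in the source may bear on it.

Measured so far in a functional assay on RAW264.7 cells (Mus musculus) for inhibition, read by Griess assay, with a stated time of 24 h (a lower number here means a stronger inhibitor, a higher number a weaker inhibitor), as follows:
- compound 1 `CC(=O)S[C@]12CC[C@H](O)[C@H]1C(=O)NC2=O` gives 833000 nM 
- compound 2 `O=C(S[C@@]12CC[C@H](O)[C@@H]1C(=O)NC2=O)c1ccccc1Cl` gives 127000 nM 
- compound 3 `O=C(S[C@]12CC[C@H](O)[C@H]1C(=O)NC2=O)c1ccccc1Cl` gives 178000 nM 

Compound 3 stands at 178000 nM in this assay and is level with compound 2 within the scatter, as the step of a 1.4-fold higher number from compound 2 to compound 3 (0.15 log units; within the scatter) shows. These two differ only in the configuration as drawn the fact that compounds 2 and 3 differ only in the configuration as drawn and, having the same configuration as compound 3, compound 4 does not draw on that step. Compound 1 has the highest number of the three.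

Compound 4 `O=C(S[C@]12CC[C@H](O)[C@H]1C(=O)NC2=O)c1ccccc1` has hydrogen in place of chloro on an aromatic carbon and so turns 2-chlorophenyl into phenyl. Among the measured compounds shown here, no measured pair isolates this change. The closest evidence is the step of a 4.7-fold lower number from compound 1 to compound 3 (0.67 log units; beyond the scatter) (2-chlorophenyl in place of methyl), which is beyond the scatter but modest. It covers the whole aryl group, so the chloro alone can be expected to carry only part of it. Any movement should therefore be small and towards a higher number.

The estimated step is a 1.3-fold higher number from compound 3 to compound 4 (0.11 log units; within the scatter) and no shift beyond the scatter is expected in this assay here. Compound 4 is estimated at 230000 nM (expected range 100000 nM to 520000 nM).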

Compound 4, half-maximal inhibitory concentration: 65200 nM
For compound 4 the middle estimate is 3.5-fold (0.55 log units) above the measured one; measured number outside the range, below it.
By their numbers in this assay, from the lowest: compounds 4, 2 and 3 (each within the scatter of the next, the first and the last beyond it); then compound 1.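

In this assay, the chloro group on an aromatic carbon, ortho to a large group, does not add to the gain from the aryl group: removing it gives a 2.7-fold lower number from compound 3 to compound 4 (0.44 log units; beyond the scatter), so at this position hydrogen is the better of the two substituents shown. The gain over the methyl of compound 1 therefore belongs to the unsubstituted phenyl, with a 13-fold lower number from compound 1 to compound 4 (1.11 log units; beyond the scatter) exceeding a 4.7-fold lower number from compound 1 to compound 3 (0.67 log units; beyond the scatter), and the chloro gives back part of that gain. The compounds shown offer nothing that accounts for the difference between chloro and hydrogen.

Going by these compounds, with only hydrogen and chloro at this position, it remains open whether fluoro, methoxy or an amine in the same place would read like compound 4 or like compound 3. Also open, on these data alone, is whether phenyl in the configuration of compound 2 would stay level with compound 4, and whether a carboxylic acid or a longer chain in place of the aryl group would extend the trend from methyl to phenyl.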